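This account rests on a few compounds, and the source may have more. Where it says the series, first, only, none or still open, it means among the compounds named here.

In an ADME assay on BJ cells (Homo sapiens) for cytotoxicity, with a stated time of 72 h (a higher number here means that more compound is needed for the effect, a lower number that less compound is needed), three compounds on a shared core return only limits and no numbers. Compound 1 `Nc1nc(-c2ccccn2)nn1-c1ncnc2ccccc12` gives > 50000 nM as a limit. Compound 2 `COCCOc1cc2ncnc(-n3nc(-c4ccccn4)nc3N)c2cc1OCCOC` gives > 27000 nM as a limit. Compound 3 `CCN(CC)c1nc(-n2nc(-c3ccccn3)nc2N)c2cc(OC)c(OC)cc2n1` gives > 9000 nM as a limit. Compound 2 thus stands without a number, as do the other two, and cannot be ranked against them. From compound 2 to compound 4 `COCCOc1cc2c(-n3nc(-c4ccccn4)nc3N)ncnc2cc1OC` the change is hydrogen in place of methoxymethyl on a saturated chain carbon bound to an oxygen on an aromatic ring and puts hydrogen in place of methoxymethyl on a saturated chain carbon bound to an oxygen on an aromatic ring. Among the compounds with values here, no measured step bears on this change, so the estimated step that the limit leaves unreadable from compound 2 to compound 4 is expected to stay within the scatter. In this assay compound 4 is estimated at 30000 nM with an expected range from 10000 nM to 60000 nM as its span.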

Compound 4, half-maximal effective concentration: > 13000 nM
Compound 4: a limit, no number (the forecaster's own chance of this, stated with the estimate: 75%); the middle value does not contradict the limit.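

Compound 2 and compound 4 both return only limits and no numbers, so no step can be read between them. The compounds shown leave open how much 2-methoxyethoxy versus methoxy matters in this assay.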